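The source may report more compounds than this note shows. Statements on the series, on what has been measured and on what is new or still open speak of the compounds shown alone.

Compound 1 `COc1ccc([C@@H]2CC(=O)c3c(O)cc(OCc4cn(Cc5ccccc5)nn4)cc3O2)cc1O` is the point of departure. In a functional assay on RAW264.7 cells (Mus musculus) for inhibition, read by Griess assay, with stated times of 2 h and 24 h (on this read-out lower numbers stand for stronger inhibition and higher numbers for weaker inhibition), compound 1 gives 11000 nM, the lowest of the three numbers recorded, though neither neighbour is separated from it beyond the scatter. Compound 2 `COc1ccc([C@@H]2CC(=O)c3c(O)cc(OCc4cn(Cc5ccc(Cl)cc5)nn4)cc3O2)cc1O` gives 17800 nM in this assay, and compound 3 `COc1ccc([C@@H]2CC(=O)c3c(O)cc(OCc4cn(Cc5ccc(F)cc5)nn4)cc3O2)cc1O` gives 15100 nM. The steps between them are small: a 1.6-fold higher number from compound 1 to compound 2 (0.21 log units; within the scatter), a 1.4-fold higher number from compound 1 to compound 3 (0.14 log units; within the scatter) and a 1.2-fold lower number from compound 2 to compound 3 (0.07 log units; within the scatter).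

Compound 4 `COc1ccc([C@@H]2CC(=O)c3c(O)cc(OCc4cn(C5CCC5)nn4)cc3O2)cc1O` differs from compound 1 in one place: cyclobutyl in place of benzyl on an aromatic nitrogen. Going by the values given here, no measured step exchanges the benzyl itself; the three steps only vary a hydrogen, chloro or fluoro on its ring, and each stays within the scatter. They therefore bear on the new change only indirectly, showing that this part of the structure has so far tolerated alteration without a clear shift in this assay. Compound 4 is thus expected to land close to compound 1, with a 1.3-fold higher number from compound 1 to compound 4 (0.10 log units; within the scatter) as the anticipated step. Compound 4 is estimated at 14000 nM, within a range of 6000 nM to 35000 nM.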

Compound 4, half-maximal inhibitory concentration: 15300 nM
Compound 4: the middle estimate sits 1.1-fold (0.04 log units) below what was measured; the measured number falls inside the stated range.
By their numbers in this assay, from the lowest: compounds 1, 3, 4 and 2 (each within the scatter of the next).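

The earlier compounds shown here varied only a substituent on the benzyl ring, whereas compound 4 replaces the whole benzyl, a group of 7 heavy atoms with a six-membered aromatic ring, by cyclobutyl, a group of 4 heavy atoms with a four-membered non-aromatic ring. In this assay this larger exchange still stays within the scatter (a 1.4-fold higher number from compound 1 to compound 4 (0.14 log units; within the scatter)), and the same is true against the two halogenated benzyl compounds (a 1.0-fold higher number from compound 3 to compound 4 (0.01 log units; within the scatter); a 1.2-fold lower number from compound 2 to compound 4 (0.07 log units; within the scatter)), so across these four compounds an aromatic ring on this nitrogen is not required for the level of inhibition seen. No evidence is available that accounts for this result. As far as these compounds go, it remains open whether an amine, a carboxylic acid or a longer chain on this nitrogen would stay within the scatter of compound 1. Also open, from the compounds shown here alone, is whether any group here can move the number clearly beyond it.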